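Swapping Bromo for Nitro: an Expectation for Compound 4

The source may hold more compounds than are shown below. What is called first, only, known or untested is meant among the compounds shown, and "the series" means these compounds.

Measured compounds:
- compound 1, `Nc1scc(-c2cccc(Br)c2)c1C(=O)c1ccccc1`, gives 76% in a functional assay on CHO cells for agonist activity at adenosine receptor A1 (Homo sapiens), read by fluorescence and ERK phosphorylation, with stated times of 30 min and 1.5 h, tested at 10 uM; a higher number here means a stronger effect of the compound at the concentration tested, a lower number a weaker effect
- compound 2, `Nc1scc(-c2cccc([N+](=O)[O-])c2)c1C(=O)c1ccccc1`, gives 50%
- compound 3, `Nc1scc(-c2cccc(Br)c2)c1C(=O)c1ccc(Cl)cc1`, gives 69%

Three compounds share one core and differ in two places. Compound 1 and compound 2 differ by nitro in place of bromo on an aromatic carbon, and this step gave a number 26 percentage points lower from compound 1 to compound 2 (beyond the scatter). Compound 1 and compound 3 differ by chloro in place of hydrogen on an aromatic carbon, and here the step was a number 7 percentage points lower from compound 1 to compound 3 (within the scatter), so the two values are not told apart by this measurement.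

Compound 4, `Nc1scc(-c2cccc([N+](=O)[O-])c2)c1C(=O)c1ccc(Cl)cc1`, has not yet been measured. It differs from compound 3 by nitro in place of bromo on an aromatic carbon. This is the same change as the one from compound 1 to compound 2, made on a core that carries the extra chloro described above; the place is described in identical words in both cases. Among the measured compounds shown here, the only guide to its size is the one step from compound 1 to compound 2, which is beyond the scatter, and whether the chloro alters the outcome cannot be known from a single example.

Starting from the value of compound 3, the expected step is a number 26 percentage points lower from compound 3 to compound 4 (beyond the scatter), estimated to match the earlier step because of a number 26 percentage points lower from compound 1 to compound 2 (beyond the scatter). Compound 4 is therefore expected to give about 43% in this assay, with a likely range from 25% to 60%.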

Compound 4, a percentage reported as activity, at one concentration (the size of the read-out at that concentration, not a potency): 42%
Compound 4: the middle estimate sits 1 percentage points above what was measured; low and high end bracket the measured number.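

On the core that carries the chloro, nitro in place of bromo on an aromatic carbon gave a number 27 percentage points lower from compound 3 to compound 4 (beyond the scatter) in this assay, and this step matches the one seen on the core without the chloro: the same change on two cores in this assay, a number 26 percentage points lower (beyond the scatter) from compound 1 to compound 2 and a number 27 percentage points lower (beyond the scatter) from compound 3 to compound 4, 1 percentage points apart, within the scatter of two such steps. Read the other way round, chloro in place of hydrogen gave a number 8 percentage points lower from compound 2 to compound 4 (within the scatter), and this step, like its earlier counterpart, does not separate the two compounds it joins, whether the ring across the core carries bromo or nitro: the same change on two cores in this assay, a number 7 percentage points lower (within the scatter) from compound 1 to compound 3 and a number 8 percentage points lower (within the scatter) from compound 2 to compound 4, 1 percentage points apart, within the scatter of two such steps. Across these four compounds the two changes therefore act independently, so the size of the nitro step carried over from one core to the other, but this rests on a single pair of cores, read at one concentration, and it shows neither why nitro gives the lower number nor that the step would hold on a core that differs in some other way.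

The compounds shown leave open how an amine, a carboxylic acid or a methoxy group in place of bromo would compare with nitro. They also leave open whether the nitro step would stay the same size with fluoro or a longer chain in place of the chloro.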